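This account rests on a few compounds, and the source may have more. Where it says the series, first, only, none or still open, it means among the compounds named here.

Compound 1 `O=C(Nc1cccc(-n2cc(-c3ccncc3)c(-c3ccc(Cl)c(O)c3)n2)c1)Nc1cccc(C(F)(F)F)c1` is tested in a functional assay on IGROV-1 cells (Homo sapiens) for inhibition, read by sulforhodamine B assay, with a stated time of 48 h (on this read-out lower numbers stand for stronger inhibition of growth and higher numbers for weaker inhibition of growth), where compound 1 gives 1640 nM. Among the three numbers at hand this is the second highest: compound 2 `O=C(Nc1cccc(-n2cc(-c3ccncc3)c(-c3ccc(Cl)c(O)c3)n2)c1)Nc1ccc(Cl)c(Cl)c1` gives 1770 nM and compound 3 `COc1cc(-c2nn(-c3cccc(NC(=O)Nc4cccc(C(F)(F)F)c4)c3)cc2-c2ccncc2)ccc1Cl` gives 1060 nM, and the steps of a 1.1-fold higher number from compound 1 to compound 2 (0.03 log units; within the scatter) and a 1.5-fold lower number from compound 1 to compound 3 (0.19 log units; within the scatter) both stay within the scatter. Compound 4 `O=C(Nc1cccc(-n2cc(-c3ccncc3)c(-c3ccc(Cl)c(O)c3)n2)c1)Nc1cc(C(F)(F)F)cc(C(F)(F)F)c1` differs from compound 1 by trifluoromethyl in place of hydrogen on an aromatic carbon. Of the measured steps, only the swap of the whole ring on the amide-type nitrogen, a 1.1-fold higher number from compound 1 to compound 2 (0.03 log units; within the scatter), concerns that part of the molecule, and it remained within the scatter; the methyl step concerns a different part. A second trifluoromethyl on that ring is therefore expected to shift the number little, if at all, beyond the scatter: compound 4 is expected at 1400 nM, with a range from 700 nM to 2800 nM, meaning a step of a 1.2-fold lower number from compound 1 to compound 4 (0.07 log units; within the scatter).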

Compound 4, concentration for 50% growth inhibition: 896 nM
Estimate against measurement, compound 4: 1.6-fold (0.19 log units) above; the measured number falls inside the stated range.
By their numbers in this assay, from the lowest: compounds 4, 3, 1 and 2 (each within the scatter of the next).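

In this assay, the aromatic carbon of the ring that already carries a trifluoromethyl group accepts a second trifluoromethyl, with a step of a 1.8-fold lower number from compound 1 to compound 4 (0.26 log units; within the scatter). Among the compounds shown here, the earlier steps swapped a whole ring or added a methyl on an oxygen, so this is the first direct look at adding a group to this carbon while the rest of compound 1 stays the same. Nothing measured here speaks to why the step stays this small.

From the compounds shown here alone, whether an amine or a carboxylic acid on this same carbon would also stay within the scatter remains open.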